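Compound 3: a 4-ethoxyphenyl for a 3-chlorophenyl

This account rests on a few compounds, and the source may have more. Where it says the series, first, only, none or still open, it means among the compounds named here.

In a functional assay on MGC-803 cells (Homo sapiens) for cytotoxicity, read by MTT assay, with a stated time of 72 h (a higher number here means a weaker inhibitor, a lower number a stronger inhibitor), compound 1 `FC(F)(F)c1ccc(CSc2nc(N3CCCCC3)c3ccccc3n2)cc1` gives 18600 nM, and compound 2 `FC(F)(F)c1ccc(CSc2nc(Nc3cccc(Cl)c3)c3ccccc3n2)cc1` gives 14600 nM. Compound 2 sits at the low end of the two numbers shown, but the step of a 1.3-fold lower number from compound 1 to compound 2 (0.11 log units; within the scatter) lies within the scatter, so the two are not separated. Compound 3 `CCOc1ccc(Nc2nc(SCc3ccc(C(F)(F)F)cc3)nc3ccccc23)cc1` differs from compound 2 by 4-ethoxyphenyl in place of 3-chlorophenyl on a nitrogen on an aromatic ring. For the measured compounds named here, the single measured step concerns piperidin-1-yl on an aromatic carbon, not the ring on a nitrogen on an aromatic ring, so no measured step bears on this change. Compound 3 is expected to show a step of a 1.0-fold lower number from compound 2 to compound 3 (0.02 log units; within the scatter), nothing beyond the scatter. In this assay compound 3 is estimated at 14000 nM, within 5000 nM to 40000 nM.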

Compound 3, half-maximal inhibitory concentration: 37000 nM
For compound 3 the middle estimate is 2.6-fold (0.42 log units) below the measured one, within the range that was stated.
By their numbers in this assay, from the lowest: compounds 2, 1 and 3 (each within the scatter of the next, the first and the last beyond it).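

In this assay, for the compounds shown here, the ring on the nitrogen turns out to matter: 4-ethoxyphenyl in place of 3-chlorophenyl gives a 2.5-fold higher number from compound 2 to compound 3 (0.40 log units; beyond the scatter) and is the first step here beyond the scatter, though a modest one. Replacing piperidin-1-yl on the aromatic carbon with (4-ethoxyphenyl)amino instead gives a 2.0-fold higher number from compound 1 to compound 3 (0.30 log units; within the scatter) and so does not separate that pair. No measurement shown explains the step. Still open, going by these compounds, is whether the step follows the ethoxy group or the loss of chlorine, and what a 4-chlorophenyl or a 4-methoxyphenyl on this nitrogen would give.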